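This account rests on a few compounds, and the source may have more. Where it says the series, first, only, none or still open, it means among the compounds named here.

Measured compounds:
- Compound 1 `c1ccc2c(c1)CN[C@@H](CN(Cc1ccc(CNC3CCOCC3)cc1)[C@H]1CCCc3cccnc31)C2`; in a functional assay on cells for agonist activity at C-X-C chemokine receptor type 4 (Homo sapiens), read by fluorescence and calcium flux, with a stated time of 90 s (a lower number here means that less compound is needed, a higher number that more compound is needed for the effect), compound 1 gives > 30000 nM, a limit of the assay.
- Compound 2 `CC1(C)CCC(NCc2ccc(CN(C[C@H]3Cc4ccccc4CN3)[C@H]3CCCc4cccnc43)cc2)CC1`; in this assay compound 2 gives > 30000 nM, a limit of the assay.
- Compound 3 `c1ccc(CNCc2ccc(CN(C[C@H]3Cc4ccccc4CN3)[C@H]3CCCc4cccnc43)cc2)nc1`; in this assay compound 3 gives > 30000 nM, a limit of the assay.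

Compound 3 stands on no number at all in this assay, only on a limit, and the same holds for every other value shown here: all three sit at the limit of > 30000 nM in this assay, at which 3 of the 3 values shown sit. The steps that lead to compound 3, a step that the two limits leave unreadable from compound 1 to compound 3 and a step that the two limits leave unreadable from compound 2 to compound 3, are unreadable between two limits, and so is the step that the two limits leave unreadable from compound 1 to compound 2 between its two neighbours. The exchange of the group on the amine nitrogen has therefore left no readable trace anywhere in the series.

Compound 4 `c1ccc2c(c1)CN[C@@H](CN(Cc1ccc(CNCc3ccncc3)cc1)[C@H]1CCCc3cccnc31)C2` differs from compound 3 by pyridin-4-yl in place of pyridin-2-yl on a saturated chain carbon bound to an amine nitrogen. Within the data shown here, no measured step touches this kind of change, and the steps around compound 3 carry no size. The only ground for an expectation is that every compound with the shared core measured so far returns a limit. Compound 4 is therefore expected to return a limit as well, at an estimated 30000 nM with a range from 10000 nM to 100000 nM. The step of a number no higher from compound 3 to compound 4 (the limit leaves the size open) is expected to be unreadable, with no shift beyond the scatter discernible.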

Compound 4, half-maximal effective concentration: > 30000 nM
Compound 4: a limit, no number; the forecaster's own chance of this, stated with the estimate: 85%; the middle value sits exactly at the limit.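

In this assay compound 4 gives > 30000 nM, a limit of the assay and not a number. No step from compound 1, compound 2 or compound 3 to compound 4 can be read, since each joins two limits: the limit of > 30000 nM in this assay, at which 4 of the 4 values shown sit.

The compounds shown leave open whether any group on this amine nitrogen of the shared core gives a readable value in this assay.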